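A Methyl Step Repeated on a Second Core

The source may hold more compounds than are shown below. What is called first, only, known or untested is meant among the compounds shown, and "the series" means these compounds.

Compound 1 `CN(C)c1ccc(Nc2nccc(-c3ccccn3)n2)cc1` gives 3300 nM in a functional assay for inhibition, with Homo sapiens as the target; on this read-out lower numbers stand for stronger inhibition and higher numbers for weaker inhibition. Compound 2 `Cc1cc(-c2ccccn2)nc(Nc2ccc(N(C)C)cc2)n1` gives 31900 nM. Compound 3 `CN(C)c1cccc(Nc2nccc(-c3ccncc3)n2)c1` gives 3700 nM.

Compound 2 differs from compound 1 by methyl in place of hydrogen on an aromatic carbon. That single change produced a 9.7-fold higher number from compound 1 to compound 2 (0.99 log units; beyond the scatter). Compound 3 is built from the same atoms as compound 1, joined differently; the difference between the two cores is not broken down here. In this assay compound 3 sits nearest compound 1 and furthest from compound 2.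

The unmeasured compound 4 `Cc1cc(-c2ccncc2)nc(Nc2cccc(N(C)C)c2)n1` differs from compound 3 by methyl in place of hydrogen on an aromatic carbon. The surroundings of the place are not identical: in compound 1 the place is meta to a pyridin-2-yl group, in compound 3 it is meta to a pyridin-4-yl group, so this is the same kind of change, not the same change.

Compound 4 is expected to show an 8.1-fold higher number from compound 3 to compound 4 (0.91 log units; beyond the scatter), an expectation resting on compound 1 and compound 2, because a 9.7-fold higher number from compound 1 to compound 2 (0.99 log units; beyond the scatter) was observed for the same kind of change. Compound 4 is thus estimated at 30000 nM, between 11000 nM and 80000 nM.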

Compound 4, half-maximal inhibitory concentration: > 24000 nM
Compound 4: a limit, no number; the forecaster's own chance of this, stated with the estimate: 10%; the middle value is on the limit's open side.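

Compound 4 gives > 24000 nM in this assay and this value is a limit of the assay, not a number. Methyl in place of hydrogen on an aromatic carbon, here opposite the ring nitrogen and meta to a pyridin-4-yl group, again gives a step beyond the scatter, with an at least 6.4-fold higher number from compound 3 to compound 4 (0.81 log units; beyond the scatter) on the core of compound 3, so the direction of the change carries over between these two cores: the same change on two cores in this assay, a 9.7-fold higher number (0.99 log units; beyond the scatter) from compound 1 to compound 2 and an at least 6.4-fold higher number (0.81 log units; beyond the scatter) from compound 3 to compound 4; the limit leaves it open whether they differ. From the compounds shown here alone, the pair does not show that the step keeps its size from one core to the other, and the true size of the second step stays unknown: the limit of > 24000 nM in this assay, at which 1 of the 4 values shown sits.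

The compounds shown leave open whether ethyl, a chlorine atom or an amine at this place would move the number the same way as methyl. Also open, going by these compounds, is whether the step would appear on cores beyond these two, and whether the number for compound 4 lies close to its limit or far past it.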